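Swapping the Amide Ring for a Methoxy Methyl Group

This account rests on a few compounds, and the source may have more. Where it says the series, first, only, none or still open, it means among the compounds named here.

Compound 2 `O=C(/C=C1\CCc2ccc(F)cc21)NC1CCC1` gives 4% in a functional assay on the whole organism with Rattus norvegicus as the target, at a dose of 20 mg/kg by the oral route; a lower number here means less inhibition, a higher number more inhibition at the dose given (going by the name of the read-out); compound 1 `O=C(/C=C1\CCc2ccc(F)cc21)N1CCCC1` gives 10%, and the two sit within the scatter of one another, as the step of a number 6 percentage points lower from compound 1 to compound 2 (within the scatter) shows. Compound 3 `CON(C)C(=O)/C=C1\CCc2ccc(F)cc21` differs from compound 2 by methoxy(methyl)amino in place of cyclobutylamino on a carbonyl carbon. Among the measured compounds shown here, the only measured step, a number 6 percentage points lower from compound 1 to compound 2 (within the scatter), also replaced the group on the carbonyl carbon and stayed within the scatter, so no step beyond the scatter is expected in this assay; the expected step is a number 3 percentage points higher from compound 2 to compound 3 (within the scatter). Compound 3 is therefore estimated at 7%, between -5% and 20%.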

Compound 3, a percentage reported as inhibition, in the whole organism at one dose (the size of the read-out at that dose, not a potency): 6%
The estimate for compound 3 lay 1 percentage points above the measured number; measured number inside the range.
By their numbers in this assay, from the lowest: compounds 2, 3 and 1 (each within the scatter of the next).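

In this assay, the step is a number 2 percentage points higher from compound 2 to compound 3 (within the scatter), and from the other ring-bearing amide it is a number 4 percentage points lower from compound 1 to compound 3 (within the scatter). Compound 3 carries no ring and no amide hydrogen on the carbonyl carbon, yet its number stays within the scatter of both, so at this place, neither feature is needed to hold the read-out at this level. No available evidence explains this result. As far as these compounds go, whether any group here can move the number beyond the scatter stays open, for example a carboxylic acid or a longer chain ending in an amine.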